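The compounds below may be only part of what the source reports. "The series", "measured", "known", "first", "only" and "open" are said of these compounds alone.

Compound 2, `Nc1ncnc2ncn(CCCO)c12`, carries a 2-hydroxyethyl group on a saturated chain carbon bound to an aromatic nitrogen. In an assay on CHO cells for displacement of a labelled ligand from adenosine receptor A3 (Homo sapiens) (a lower number here means a stronger inhibitor, a higher number a weaker inhibitor), compound 2 gives > 100000 nM, which is a limit of the assay and not a number. Compound 1, `CC(C)Cn1cnc2ncnc(N)c21`, has an isopropyl group in that place. In this assay compound 1 gives > 100000 nM, again a limit rather than a number. The step that the two limits leave unreadable from compound 1 to compound 2 is therefore of unreadable size, and all the two values show is the limit of > 100000 nM in this assay, at which 2 of the 2 values shown sit.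

Compound 3, `CC(O)Cn1cnc2ncnc(N)c21`, differs from compound 2 in that (1-hydroxyethyl in place of 2-hydroxyethyl on a saturated chain carbon bound to an aromatic nitrogen). For the measured compounds named here, no measured step bears on this rearrangement, since the only step available is the one from compound 1 to compound 2 and it cannot be read. Both compounds whose values are known sit at the limit, and the shared core is unchanged, so compound 3 is expected to remain at the weak end of this assay, with an expected step of a number no higher from compound 2 to compound 3 (the limit leaves the size open). The estimate for compound 3 in this assay is 100000 nM, between 30000 nM and 300000 nM.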

Compound 3, inhibition constant: > 100000 nM
Compound 3 was reported as a limit; the forecaster's own chance of this, stated with the estimate: 80%; the middle value lies on the limit itself.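

No step among compound 1, compound 2 and compound 3 can be read, since each is reported only as a limit of the assay in this assay: the limit of > 100000 nM in this assay, at which 3 of the 3 values shown sit.

The compounds shown leave open how strong any of the three is as an inhibitor, and whether 1-hydroxyethyl in place of 2-hydroxyethyl makes any difference in this assay.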